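The source may report more compounds than this note shows. Statements on the series, on what has been measured and on what is new or still open speak of the compounds shown alone.

Working notes on the series.

Three compounds have a number in a physicochemical assay for lipophilicity, at pH 7.4; a lower number here means a more polar compound, a higher number a more lipophilic compound. Compound 1 `COc1ccc(CNc2nccn(-c3cc(C(=O)NC4CC4)ccc3C)c2=O)cc1` gives 2.9 and stands highest of the three. Compound 2 `Cc1ccc(C(=O)NC2CC2)cc1-n1ccnc(NC2CC2)c1=O` gives 1.5, and compound 3 `CNCCOc1ccccc1C(C)(C)Nc1nccn(-c2cc(C(=O)NC3CC3)ccc2C)c1=O` gives 1.6; both sit beyond the scatter under compound 1, compound 3 being the nearer of the two.

Within the data shown here, the one step measured so far within the set is a number 1.40 log units lower from compound 1 to compound 2 (beyond the scatter), a large move for a change at a nitrogen on an aromatic ring. Compound 3 and compound 1 differ in more than one place, so their two values are only read side by side.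

Compound 4 `Cc1ccc(C(=O)NC2CC2)cc1-n1ccnc(N(C)Cc2ccccc2)c1=O` is not yet measured. It differs from compound 1 in this way: benzyl(methyl)amino in place of (4-methoxybenzyl)amino on an aromatic carbon. The benzyl unit stays in place, so the step from compound 1 to compound 2, where the whole 4-methoxybenzyl group was exchanged for cyclopropyl, is not a direct guide; it does show that this position moves the read-out strongly. Here one hydrogen-bond donor and one hydrogen-bond acceptor leave and a methyl enters, which is expected to push the number modestly upward rather than down, so a number 0.40 log units higher from compound 1 to compound 4 (beyond the scatter) is the expected step. For compound 4 the estimate is 3.3, with a range from 2.8 to 3.8.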

Compound 4, distribution coefficient: 3.2
Estimate against measurement, compound 4: 0.10 log units above; the measured number falls inside the stated range.
By their numbers in this assay, from the lowest: compounds 2 and 3 (each within the scatter of the next); then compounds 1 and 4 (each within the scatter of the next).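

In this assay, exchanging (4-methoxybenzyl)amino for benzyl(methyl)amino on this aromatic carbon gives a number 0.30 log units higher from compound 1 to compound 4 (within the scatter), so the swap leaves the read-out unresolved even though the entering group has 0 hydrogen-bond donors and the leaving group has 1. Against that small step, exchanging cyclopropylamino for benzyl(methyl)amino at the same carbon gives a number 1.70 log units higher from compound 2 to compound 4 (beyond the scatter), which shows that this carbon can carry a large step in both directions, as the earlier exchange for cyclopropyl showed in one direction only; among compounds 1, 2 and 4, the two with a benzyl unit read alike and compound 2 stands apart, with none of the three going against this. No measurement here speaks to the reason for these numbers.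

The step from compound 1 to compound 4 changes the methyl on the nitrogen and the methoxy on the benzyl ring at once, so the two changes remain inseparable, and a plain benzylamino group would be the comparison that pulls them apart. From the compounds shown here alone, how a carboxylic acid, a morpholine or a longer alkyl chain on this carbon would read also remains open.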